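The source may report more compounds than this note shows. Statements on the series, on what has been measured and on what is new or still open speak of the compounds shown alone.

Of the compounds shown here, two sharing one core have been measured in an ADME assay on L02 cells (Homo sapiens) for antiproliferative activity, read by MTT assay, with a stated time of 48 h; a lower number here means a stronger inhibitor, a higher number a weaker inhibitor. Compound 1 `CC(=O)Nc1ccc(-n2nncc2CN2C(=O)C3(C(C#N)=C(N)Oc4c3c3nc5ccccc5nc3c3ccccc43)c3ccccc32)cc1` carries a 4-acetamidophenyl group on an aromatic nitrogen. In this assay compound 1 gives > 50000 nM, which is a limit of the assay rather than a measured number. Compound 2 `CC(=O)Nc1ccc(-n2nncc2CN2C(=O)C3(C(C#N)=C(N)Oc4c(N)cc5nc6ccccc6nc5c43)c3ccccc32)cc1` has the same 4-acetamidophenyl group but differs from compound 1 in the core. In this assay compound 2 gives > 50000 nM, again a limit and not a number. Among the measured compounds shown here, compound 2 therefore stands where the only other value also stands: the limit of > 50000 nM in this assay, at which 2 of the 2 values shown sit. For the measured compounds named here, no step between two measured compounds is available, so the data contain nothing on how any single change moves the numbers here.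

Compound 3 `N#CC1=C(N)Oc2c(N)cc3nc4ccccc4nc3c2C12C(=O)N(Cc1cnnn1-c1ccc([N+](=O)[O-])cc1[N+](=O)[O-])c1ccccc12` has not yet been measured. It differs from compound 2 in one place: 2,4-dinitrophenyl in place of 4-acetamidophenyl on an aromatic nitrogen. With both measured compounds sitting at the limit, no direction can be drawn from them, and the step is expected to be none beyond the scatter. The expected step of a number no higher from compound 2 to compound 3 (the limit leaves the size open) is small. Compound 3 is therefore expected to give roughly 50000 nM in this assay, with a likely range from 20000 nM to 120000 nM, and most probably the assay will again report only a limit.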

Compound 3, half-maximal inhibitory concentration: 22800 nM
Beside the measured number, compound 3's estimate is 2.2-fold (0.34 log units) above it, and the stated range covers the measured number.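

In this assay, the group on the aromatic nitrogen of the five-membered ring can now be seen to move the read-out: 2,4-dinitrophenyl in place of 4-acetamidophenyl gives an at least 2.1-fold lower number from compound 2 to compound 3 (0.34 log units; beyond the scatter). Among the compounds shown here, compound 3 is the only compound here with a measured number rather than a limit, which shows that the core of compound 2 can give a measurable result in this assay when this group is changed. The true size of the step stays unknown, since it starts from a limit and not a number: the limit of > 50000 nM in this assay, at which 2 of the 3 values shown sit.

The change removes the acetamido group and brings in two nitro groups at once, and the compounds shown cannot separate these parts or say whether a single nitro group or a plain phenyl ring would give a similar result. They also leave open how an amine or a carboxylic acid on that phenyl ring would read, and whether 2,4-dinitrophenyl would lower the number on the core of compound 1 as well.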